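Changing the Aryl Group on the Amine of Compound 2

A few compounds are considered here, and "the series" means these few. Any claim that something is new, unique, unknown or untested is made for them only; others in the source may bear on it.

Compound 1 `COc1ccc(Nc2cc(Nc3ccc(Oc4ccncc4-c4cccnc4)c(F)c3)ncn2)cc1`: 2140 nM
Compound 2 `Fc1ccc(Nc2cc(Nc3ccc(Oc4ccncc4-c4cccnc4)c(F)c3)ncn2)cc1F`: 7630 nM

In a functional assay on A549 cells (Homo sapiens) for cytotoxicity, read by MTT assay, with a stated time of 72 h (a higher number here means a weaker inhibitor, a lower number a stronger inhibitor), compound 1 gives 2140 nM, whereas compound 2 gives 7630 nM. Compound 2 therefore stands highest of the two numbers shown, and its nearest neighbour is compound 1, reached by the single measured step of a 3.6-fold higher number from compound 1 to compound 2 (0.55 log units; beyond the scatter).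

Compound 3 `Fc1cc(Nc2cc(Nc3ccc(Cl)cc3)ncn2)ccc1Oc1ccncc1-c1cccnc1` is the next member of this pair of aromatic amines. It differs from compound 2 in one place: 4-chlorophenyl in place of 3,4-difluorophenyl on a nitrogen on an aromatic ring. Among the measured compounds shown here, the only step that bears on this position, a 3.6-fold higher number from compound 1 to compound 2 (0.55 log units; beyond the scatter), shows that exchanging one aryl group for another at this nitrogen can shift the number beyond the scatter. For the measured compounds named here, no measured step involves 4-chlorophenyl itself, so the direction for compound 3 is uncertain; a shift no larger than the one already seen is the reasonable expectation.

On that basis compound 3 is expected to give about 4500 nM in this assay, within a range of 1500 nM to 13000 nM, an estimated step of a 1.7-fold lower number from compound 2 to compound 3 (0.23 log units; within the scatter).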

Compound 3, half-maximal inhibitory concentration: 1610 nM
Compound 3: middle estimate off by 2.8-fold (0.45 log units), on the high side; the range from low to high includes it.
By their numbers in this assay, from the lowest: compounds 3 and 1 (each within the scatter of the next); then compound 2.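

Replacing 3,4-difluorophenyl with 4-chlorophenyl on this nitrogen lowers the number in this assay, with a 4.7-fold lower number from compound 2 to compound 3 (0.68 log units; beyond the scatter), so the earlier rise seen with 3,4-difluorophenyl is not a shift that every other aryl group reverses only slightly or leaves in place. The two compounds carrying 4-methoxyphenyl and 4-chlorophenyl cannot be told apart, with a 1.3-fold lower number from compound 1 to compound 3 (0.12 log units; within the scatter), which means that chloro and methoxy on this aromatic carbon serve equally well here and compound 2 is the weakest of the three. Nothing available explains why 3,4-difluorophenyl stands apart from the other two aryl groups.

Among the compounds shown here, with only three aryl groups in view, it remains open whether the difference follows from the second fluorine, from the fluorine in place of chloro or methoxy, or from both, and a 4-fluorophenyl or 3-fluorophenyl group would separate these readings. As far as these compounds go, it is also open whether a plain phenyl, a pyridyl ring or a non-aromatic group such as cyclohexyl on this nitrogen would give a number like that of compound 3 or one like that of compound 2.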